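The source may hold more compounds than are shown below. What is called first, only, known or untested is meant among the compounds shown, and "the series" means these compounds.

Among the compounds with values here, compound 3 `O=C(CN1CCN(c2nnc(Cc3ccncc3)c3ccccc23)CC1)Nc1c(F)cccc1F` gives 54400 nM in a functional assay on A549 cells (Homo sapiens) for cytotoxicity, read by MTT assay, with a stated time of 72 h (on this read-out higher numbers stand for weaker inhibition and lower numbers for stronger inhibition), the highest of the three numbers known here, and so the weakest inhibitor of the three. Compound 1 `O=C(CN1CCN(c2nnc(Cc3ccncc3)c3ccccc23)CC1)Nc1cccc(Br)c1` gives 1530 nM in this assay, and compound 2 `O=C(CN1CCN(c2nnc(Cc3ccncc3)c3ccccc23)CC1)Nc1cc(C(F)(F)F)ccc1Cl` gives 1850 nM in this assay; these two lie within the scatter of each other, with a 1.2-fold higher number from compound 1 to compound 2 (0.08 log units; within the scatter). Compound 3 stands apart from both: a 36-fold higher number from compound 1 to compound 3 (1.55 log units; beyond the scatter) and a 29-fold higher number from compound 2 to compound 3 (1.47 log units; beyond the scatter). Compound 4 `COc1ccc(NC(=O)CN2CCN(c3nnc(Cc4ccncc4)c4ccccc34)CC2)cc1OC` has not yet been measured in this assay. The change is 3,4-dimethoxyphenyl in place of 2,6-difluorophenyl on an amide-type nitrogen. Within the data shown here, no measured step covers this pair directly, but the two large steps show that 2,6-difluorophenyl on the amide-type nitrogen sits far above every other aryl group seen here. Because a 36-fold higher number from compound 1 to compound 3 (1.55 log units; beyond the scatter) and a 29-fold higher number from compound 2 to compound 3 (1.47 log units; beyond the scatter) are both large, taking that group away is expected to bring the number down, though whether 3,4-dimethoxyphenyl reaches the level of compound 1 and compound 2 is not shown. Compound 4 is therefore expected to give 4500 nM in this assay, within a range of 1300 nM to 20000 nM. The estimated step is a 12-fold lower number from compound 3 to compound 4 (1.08 log units; beyond the scatter).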

Compound 4, half-maximal inhibitory concentration: 26500 nM
The estimate for compound 4 lay 5.9-fold (0.77 log units) below the measured number; the whole stated range lies below it.
By their numbers in this assay, from the lowest: compounds 1 and 2 (each within the scatter of the next); then compound 4; then compound 3.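

In this assay, a 17-fold higher number from compound 1 to compound 4 (1.24 log units; beyond the scatter) and a 14-fold higher number from compound 2 to compound 4 (1.16 log units; beyond the scatter) show that 3,4-dimethoxyphenyl does not join 3-bromophenyl and 2-chloro-5-(trifluoromethyl)phenyl on the amide-type nitrogen. The exchange for 2,6-difluorophenyl gives only a modest gain (a 2.1-fold lower number from compound 3 to compound 4 (0.31 log units; beyond the scatter)), so high numbers at this position are no longer confined to 2,6-difluorophenyl, and the aryl groups seen here now divide into two separated levels. Nothing available accounts for this separation.

As far as these compounds go, it remains open whether a single methoxy group on the phenyl ring would give a number nearer compound 4 or nearer compound 1. The four compounds also leave open how an unsubstituted phenyl, a carboxylic acid on the ring, or a dimethylamino group on the ring would fall relative to these two levels.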